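A few compounds are considered here, and "the series" means these few. Any claim that something is new, unique, unknown or untested is made for them only; others in the source may bear on it.

In a functional assay on PC-3 cells (Homo sapiens) for inhibition, read by sulforhodamine B assay (on this read-out higher numbers stand for weaker inhibition of growth and lower numbers for stronger inhibition of growth), compound 1 (`CC(=O)Nc1ccc(CN2CCC=C(CCC(=O)NO)C2=O)cc1`) gives > 10000 nM as a limit and not as a number. Compound 2 (`O=C(CCC1=CCCN(Cc2ccc(NC(=O)c3ccccc3)cc2)C1=O)NO`) likewise gives > 10000 nM as a limit and has no number of its own. Phenyl in place of methyl on a carbonyl carbon is thus a step that the two limits leave unreadable from compound 1 to compound 2 and offers no size to carry forward. All that the series shows so far is one result (the limit of > 10000 nM in this assay, at which 2 of the 2 values shown sit) and no graded value. Compound 3 (`O=C(CCC1=CCCN(Cc2ccc([N+](=O)[O-])cc2)C1=O)NO`) alters compound 2 at a single place (nitro in place of benzamido on an aromatic carbon), with nitro in place of benzamido on an aromatic carbon, para to a large group. Going by the values given here, no measured step bears on this exchange, so the data give neither a size nor a direction, and the expected step (a step that the limit leaves unreadable from compound 2 to compound 3) in this assay is only a rough estimate that stays near that limit. Compound 3 is estimated at 15000 nM with an expected range from 4000 nM to 50000 nM and a limit is the likeliest result.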

Compound 3, concentration for 50% growth inhibition: 3010 nM
Estimate against measurement, compound 3: 5.0-fold (0.70 log units) above; measured number outside the range, below it.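

In this assay, the position on the aromatic carbon now proves able to shift the read-out: nitro in place of benzamido gives an at least 3.3-fold lower number from compound 2 to compound 3 (0.52 log units; beyond the scatter), and nitro in place of acetamido gives an at least 3.3-fold lower number from compound 1 to compound 3 (0.52 log units; beyond the scatter). Both exchanges therefore run in the same direction and lie beyond the scatter, although their full size cannot be read, and the step between the two amides stays unreadable. Compound 3 is the only compound with a graded value, while the others remain at one limit: the limit of > 10000 nM in this assay, at which 2 of the 3 values shown sit.

On these data alone, how far the number would fall with the amides measured as true values remains open, as does whether the lower number belongs to nitro alone. An amine or a nitrile on that aromatic carbon could show whether other small groups give a graded value as well.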